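Swapping the sulfonyl aryl group: compound 2 to compound 4

The source may hold more compounds than are shown below. What is called first, only, known or untested is meant among the compounds shown, and "the series" means these compounds.

Of the compounds shown here, three with a shared core have been tested in an ADME assay on microsomes from liver (Homo sapiens) for metabolic stability, tested at 2.5 uM; a lower number here means slower removal, a higher number faster removal of the compound. Compound 1 `O=S(=O)(c1ccc(F)c(Cl)c1)c1cnc2cc(F)ccc2c1-c1ccc(Cl)cc1` gives 0.39 mL/min in this assay. Compound 2 `O=S(=O)(c1ccc(F)cc1)c1cnc2cc(F)ccc2c1-c1cccc(F)c1` gives 0.95 mL/min, and compound 3 `O=S(=O)(c1cccc(F)c1)c1cnc2c(F)cccc2c1-c1cccc(Cl)c1` gives 0.56 mL/min. Of the three numbers, that of compound 2 is the largest, but its gap to compound 3 falls within the usual scatter, and only its gap to compound 1 lies beyond it.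

Compound 4 `COc1cccc(S(=O)(=O)c2cnc3cc(F)ccc3c2-c2cccc(F)c2)c1` has not yet been measured in this assay. It differs from compound 2 in one place: 3-methoxyphenyl in place of 4-fluorophenyl on a sulfonyl sulfur. Among the compounds with values here, no measured pair among the three compounds carries this same change, so nothing here shows directly how the swap plays out in this assay.

The expectation for compound 4 therefore rests on compound 2 alone, with the change of aryl group on the sulfonyl sulfur taken as likely to push the number somewhat upward, though a step that stays within the scatter cannot be ruled out. The step from compound 2 to compound 4 is estimated as a 1.4-fold higher number from compound 2 to compound 4 (0.14 log units; within the scatter) in this assay. Compound 4 is expected to give about 1.3 mL/min, with a range from 0.6 mL/min to 2.8 mL/min.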

Compound 4, intrinsic clearance in a liver preparation (reported as CLH), per the amount of preparation that the assay uses: 3.36 mL/min
Estimate against measurement, compound 4: 2.6-fold (0.41 log units) below; the whole stated range lies below it.
By their numbers in this assay, from the lowest: compounds 1, 3 and 2 (each within the scatter of the next, the first and the last beyond it); then compound 4.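

Within the data shown here, until this result, no two measured compounds differed in a single place, so nothing showed what the aryl group on the sulfonyl sulfur does on its own. Placing 3-methoxyphenyl in place of 4-fluorophenyl on a sulfonyl sulfur, with the rest of the molecule unchanged, gives a 3.5-fold higher number from compound 2 to compound 4 (0.55 log units; beyond the scatter) in this assay and is the first single-change step here, one that clearly exceeds the usual spread of repeat measurements. It shows that the number in this assay responds to this position, and that this swap moves it towards faster removal, yet nothing among the data shown speaks to the reason for the rise.

Going by these compounds, this single step cannot separate the loss of the fluorine from the arrival of the methoxy group, and how a plain phenyl, an ethoxy group, a hydroxyl or an amine on that aryl ring would read remains open. Also open, on these data alone, is whether the same swap gives a similar step on the compounds that carry other groups elsewhere on the shared core, such as compound 1 and compound 3.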